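Nitro on the aryl ring of a cyclopropane sigma ligand

The source may hold more compounds than are shown below. What is called first, only, known or untested is meant among the compounds shown, and "the series" means these compounds.

Measured compounds:
Compound 1, `COC(=O)C1(c2ccc([N+](=O)[O-])cc2)CC1CN1CCN(c2ccccn2)CC1`, gives 769 nM.
Compound 2, `COC(=O)C1(c2ccccc2)CC1CN1CCC(Cc2ccccc2)CC1`, gives 2.2 nM.
Compound 3, `COC(=O)C1(c2ccccc2)CC1CN1CCN(c2ccccn2)CC1`, gives 1330 nM.

All three were tested in an assay for displacement of a labelled ligand from Sigma non-opioid intracellular receptor 1 (Cavia porcellus); a lower number here means a stronger inhibitor, a higher number a weaker inhibitor. Compound 3 and compound 1 share one core and differ in a single place: nitro in place of hydrogen on an aromatic carbon. That change gave a 1.7-fold lower number from compound 3 to compound 1 (0.24 log units; within the scatter), so on this core the nitro group left the number essentially where it was.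

Compound 2 carries a different core. How it differs from the core of compound 3 is not broken down here. In this assay compound 2 gives a number far lower than either compound 1 or compound 3, and both gaps lie beyond the scatter, which makes compound 2 the strongest inhibitor of the three measured.

Compound 4, `COC(=O)C1(c2ccc([N+](=O)[O-])cc2)CC1CN1CCC(Cc2ccccc2)CC1`, has not yet been measured. It differs from compound 2 in one place: nitro in place of hydrogen on an aromatic carbon. This is the same change that turns compound 3 into compound 1, at the same kind of place on the aromatic ring. Within the data shown here, because that earlier step was a 1.7-fold lower number from compound 3 to compound 1 (0.24 log units; within the scatter), the expectation for compound 4 is a step of similar size, that is a 1.1-fold lower number from compound 2 to compound 4 (0.04 log units; within the scatter), resting on the single precedent from compound 3 to compound 1 alone. The estimate for compound 4 in this assay is therefore 2 nM, with a likely range from 0.7 nM to 6 nM.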

Compound 4, inhibition constant: 0.68 nM
Compound 4: middle estimate off by 2.9-fold (0.47 log units), on the high side; the whole stated range lies above it.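

In this assay, putting nitro in place of hydrogen on the aromatic ring gave a 3.2-fold lower number from compound 2 to compound 4 (0.51 log units; beyond the scatter), a modest step but one larger than repeat measurements would usually produce by chance. Set beside the earlier step, this result cannot be told apart from it, so the change carried over from one core to the other with no measurable difference in size: the same change on two cores in this assay, a 1.7-fold lower number (0.24 log units; within the scatter) from compound 3 to compound 1 and a 3.2-fold lower number (0.51 log units; beyond the scatter) from compound 2 to compound 4, 1.9-fold (0.27 log units) apart, within the scatter of two such steps. This shows agreement between two cores with one step each, but it does not show that the change truly does more on the core of compound 2 than on the core of compound 3, nor that a third core would behave the same way.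

The compounds shown carry only nitro or hydrogen at this place on the ring, so it remains open whether an amine, a nitrile or a methoxy group para to the same large group would give a step of similar size and direction. It also remains open whether the step would hold if the methyl ester of these compounds gave way to a carboxylic acid or an amide.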